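Thiol-linker phloretin series: glycoside versus free phenol

The compounds below may be only part of what the source reports. "The series", "measured", "known", "first", "only" and "open" are said of these compounds alone.

Measured so far in a functional assay on HCT-116 cells (Homo sapiens) for cytotoxicity, read by sulforhodamine B assay, with a stated time of 48 h; on this read-out lower numbers stand for stronger inhibition and higher numbers for weaker inhibition:
compound 1 `O=C(CCCCCN1C(=O)CC(SCCOCCOCCOc2cc(O)c(C(=O)CCc3ccc(O)cc3)c(O)c2)C1=O)OCn1cc(F)c(=O)[nH]c1=O` gives 75000 nM
compound 2 `O=C(CCCSSCCOCCOCCOc1cc(O)c(C(=O)CCc2ccc(O)cc2)c(O)c1)OCn1cc(F)c(=O)[nH]c1=O` gives 21200 nM
compound 3 `O=C(CCc1ccc(O)cc1)c1c(O)cc(OCCOCCOCCS)cc1O[C@@H]1O[C@H](CO)[C@@H](O)[C@H](O)[C@H]1O` gives only a limit, > 100000 nM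

Compound 3 therefore stands at the top of the range seen here: its result is a limit of this assay, not a number (the limit of > 100000 nM in this assay, at which 1 of the 3 values shown sits). Compound 1 and compound 2 carry numbers, both weak. Compound 4 `O=C(CCc1ccc(O)cc1)c1c(O)cc(OCCOCCOCCS)cc1O` is compound 3 with hydrogen in place of 3,4,5-trihydroxy-6-(hydroxymethyl)oxan-2-yl on an oxygen on an aromatic ring. Among the measured compounds shown here, no measured pair shows this change, so the direction is open; a step from compound 3 to compound 4 of about an at least 1.2-fold lower number from compound 3 to compound 4 (0.09 log units; that floor lies within the scatter) toward stronger inhibition is expected, which may stay within the scatter. Compound 4 is estimated at 80000 nM, between 30000 nM and 200000 nM.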

Compound 4, half-maximal inhibitory concentration: 15500 nM
Compound 4: the middle estimate sits 5.2-fold (0.71 log units) above what was measured; the measured number lies below the stated range.
By their numbers in this assay, from the lowest: compounds 4 and 2 (each within the scatter of the next); then compound 1. At a limit, above all of these: compound 3.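

In this assay, among the compounds shown here, hydrogen in place of 3,4,5-trihydroxy-6-(hydroxymethyl)oxan-2-yl on an oxygen on an aromatic ring gives an at least 6.4-fold lower number from compound 3 to compound 4 (0.80 log units; beyond the scatter), the first measured pair and one that sets a direction for this change: toward stronger inhibition. The result for compound 3 is a limit, so the size of this step is only a floor: the limit of > 100000 nM in this assay, at which 1 of the 4 values shown sits.

From the compounds shown here alone, it remains open whether a smaller group on this oxygen, such as methyl or acetyl, would read closer to compound 4 or to compound 3. Going by these compounds, the effect of a longer chain in the shared linker also remains open.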